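Amide-linked piperazine series: aromatic group replaces basic ring

The compounds below may be only part of what the source reports. "The series", "measured", "known", "first", "only" and "open" are said of these compounds alone.

Compound 1 `CCCCN1CCN(CCC(=O)Nc2nc3c(C)cccc3s2)CC1` in an assay on membranes from liver for displacement of a labelled ligand from Sigma intracellular receptor 2 (Rattus norvegicus), read by scintillation counting, with a stated time of 120 min; on this read-out lower numbers stand for stronger inhibition and higher numbers for weaker inhibition: 1200 nM
Compound 2 `Cc1cccc2sc(NC(=O)CCN3CCN(CCCN(C)C)CC3)nc12` in this assay: > 1000 nM, a limit of the assay and not a number.
Compound 3 `Cc1cccc2sc(NC(=O)CCN3CCN(C4CCN(C)CC4)CC3)nc12` in this assay: 3600 nM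

Going by the values given here, compound 3 carries the higher of the two numbers read; its nearest neighbour is compound 1, and the step of a 3.0-fold higher number from compound 1 to compound 3 (0.48 log units; beyond the scatter) is the only readable step in the set. Compound 2 sits at the limit of > 1000 nM in this assay, at which 1 of the 3 values shown sits. Hence a step that the limit leaves unreadable from compound 1 to compound 2 and a step that the limit leaves unreadable from compound 2 to compound 3 cannot be sized.

Compound 4 `Cc1ccccc1N1CCN(CCC(=O)Nc2nc3c(C)cccc3s2)CC1` differs from compound 3 by 2-methylphenyl in place of 1-methylpiperidin-4-yl on an amine nitrogen in a ring. Among the compounds with values here, no measured step places an aromatic group on this nitrogen; the only change recorded there is butyl to 1-methylpiperidin-4-yl, which raised the number modestly in a 3.0-fold higher number from compound 1 to compound 3 (0.48 log units; beyond the scatter). The direction for compound 4 is therefore open, and the scale of that one step is taken as the working scale. Compound 4 is expected near 700 nM, within 150 nM to 3000 nM. This amounts to an expected step of a 5.1-fold lower number from compound 3 to compound 4 (0.71 log units; beyond the scatter), leaning toward a lower number but with wide uncertainty.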

Compound 4, inhibition constant: > 1000 nM
Compound 4: no number, only a limit (the forecaster's own chance of this, stated with the estimate: 10%); middle value at least 1.4-fold (0.15 log units) from the limit.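

In this assay compound 4 gives > 1000 nM, a limit of the assay and not a number, so its steps from compound 1, compound 2 and compound 3 cannot be read: the limit of > 1000 nM in this assay, at which 2 of the 4 values shown sit.

The compounds shown leave open how 2-methylphenyl compares with butyl or 1-methylpiperidin-4-yl on this amine nitrogen in a ring.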